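Piperazine Addition Carried from One Core to Another

The source may report more compounds than this note shows. Statements on the series, on what has been measured and on what is new or still open speak of the compounds shown alone.

Measured compounds in a functional assay on MDA-MB-231 cells (Homo sapiens) for cytotoxicity, read by MTT assay, with a stated time of 72 h; on this read-out lower numbers stand for stronger inhibition and higher numbers for weaker inhibition:
compound 1, `COc1cc(Nc2nc(C(=N)Nc3ccc(N4CCN(C)CC4)cc3)cc3c(-c4ccccc4)n[nH]c23)cc(OC)c1OC`, 4600 nM
compound 2, `COc1cc(Nc2nc(C(=N)Nc3ccccc3)cc3c(-c4ccccc4)n[nH]c23)cc(OC)c1OC`, 4500 nM
compound 3, `COc1ccc(Cn2nc(-c3ccccc3)c3cc(C(=N)Nc4ccccc4)nc(NC4CCCCC4)c32)cc1`, 3400 nM

Compound 1 and compound 2 share one core; compound 3 carries a different core, and the difference between the two cores is not broken down here. Compound 1 differs from compound 2 by 4-methylpiperazin-1-yl in place of hydrogen on an aromatic carbon, and in this assay this gave a 1.0-fold higher number from compound 2 to compound 1 (0.01 log units; within the scatter). Compound 4, `COc1ccc(Cn2nc(-c3ccccc3)c3cc(C(=N)Nc4ccc(N5CCN(C)CC5)cc4)nc(NC4CCCCC4)c32)cc1`, is not yet measured. It differs from compound 3 by 4-methylpiperazin-1-yl in place of hydrogen on an aromatic carbon, the same change at the same kind of place. Because the earlier step was a 1.0-fold higher number from compound 2 to compound 1 (0.01 log units; within the scatter), the step from compound 3 to compound 4 is expected to be a 1.0-fold higher number from compound 3 to compound 4 (0.01 log units; within the scatter). Compound 4 is therefore estimated at 3500 nM in this assay, resting on a single earlier instance of this change.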

Compound 4, half-maximal inhibitory concentration: 129000 nM
Compound 4: middle estimate off by 37-fold (1.57 log units), on the low side; the measured number lies above the stated range.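

In this assay, the same addition of 4-methylpiperazin-1-yl that changed little on the core of compound 2 gave a 38-fold higher number from compound 3 to compound 4 (1.58 log units; beyond the scatter), so the change did not carry over from one core to the other: the same change on two cores in this assay, a 1.0-fold higher number (0.01 log units; within the scatter) from compound 2 to compound 1 and a 38-fold higher number (1.58 log units; beyond the scatter) from compound 3 to compound 4, 37-fold (1.57 log units) apart, beyond the scatter of two such steps. This shows that, for these two pairs, the outcome of the change depends on the core it is made on. Among these compounds, it does not show which difference between the cores is responsible, and each core offers only a single instance of the change.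

The compounds shown leave open whether a morpholine or a dimethylamino group at the same place on the core of compound 3 would give a step of similar size. They also leave open how the change would behave on any third core.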